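The compounds below may be only part of what the source reports. "The series", "measured", "known", "first", "only" and "open" are said of these compounds alone.

Working notes on the thiosemicarbazone series in a functional assay on DU-145 cells (Homo sapiens) for cytotoxicity, read by MTT assay, with a stated time of 72 h; on this read-out lower numbers stand for stronger inhibition and higher numbers for weaker inhibition.

Three compounds of the shared core have been run. Compound 1 `CCCNC(=S)N/N=C1\CC(c2ccc(O)cc2)Oc2cc(O)ccc21` gives 74700 nM in this assay. Compound 2 `CCCN(CCC)C(=S)N/N=C1\CC(c2ccc(O)cc2)Oc2cc(O)ccc21` gives 62100 nM, and compound 3 `Oc1ccc(C2C/C(=N\NC(=S)N3CCCCC3)c3ccc(O)cc3O2)cc1` gives 55300 nM. Compound 1 holds the highest of the three numbers, but the step of a 1.2-fold lower number from compound 1 to compound 2 (0.08 log units; within the scatter) and the step of a 1.4-fold lower number from compound 1 to compound 3 (0.13 log units; within the scatter) both sit within the scatter, and so does the step of a 1.1-fold lower number from compound 2 to compound 3 (0.05 log units; within the scatter); on these numbers the three compounds cannot be told apart.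

The next compound is compound 4 `Oc1ccc(C2C/C(=N\NC(=S)N3CCOCC3)c3ccc(O)cc3O2)cc1`, which differs from compound 1 in one place: morpholin-4-yl in place of propylamino on a thiocarbonyl carbon.

The step that bears most directly on it is a 1.4-fold lower number from compound 1 to compound 3 (0.13 log units; within the scatter), where a six-membered ring of one hetero atom took the place of propylamino on the same thiocarbonyl carbon and changed nothing beyond the scatter. The step of a 1.2-fold lower number from compound 1 to compound 2 (0.08 log units; within the scatter) shows the same: filling the nitrogen of that group with propyl in place of hydrogen left the number where it was. Among the compounds with values here, nothing among the measured steps points to a shift in either direction, so the step from compound 1 to compound 4 in this assay is expected to be a 1.2-fold lower number from compound 1 to compound 4 (0.10 log units; within the scatter), within the scatter.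

Compound 4 is accordingly estimated at 60000 nM, with a range of 30000 nM to 120000 nM.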

Compound 4, half-maximal inhibitory concentration: 84500 nM
Beside the measured number, compound 4's estimate is 1.4-fold (0.15 log units) below it, and the stated range covers the measured number.
By their numbers in this assay, from the lowest: compounds 3, 2, 1 and 4 (each within the scatter of the next).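

In this assay, the thiocarbonyl carbon now carries a ring with a second hetero atom, and the change from propylamino to morpholin-4-yl removes a hydrogen-bond donor and adds a hydrogen-bond acceptor, yet a 1.1-fold higher number from compound 1 to compound 4 (0.05 log units; within the scatter) stays within the scatter. The closest comparison, a swap of piperidin-1-yl for morpholin-4-yl, gives a 1.5-fold higher number from compound 3 to compound 4 (0.18 log units; within the scatter), and the change from the open chains of dipropylamino gives a 1.4-fold higher number from compound 2 to compound 4 (0.13 log units; within the scatter), so neither the added ring oxygen nor the ring itself separates compound 4 from the others. Across the four groups now seen at this position, open-chain or ring-closed, with or without a donor or an acceptor, no step leaves the scatter, and nothing on hand bears on why these numbers stay together.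

Still open, from the compounds shown here alone, is whether a group of a different kind on the thiocarbonyl carbon, such as phenylamino or a piperazin-1-yl ring carrying a second amine, would move the number beyond the scatter. Also open, going by these compounds, is whether replacing the hydroxyl groups of the shared core with methoxy would have any effect where changes at the thiocarbonyl carbon have had none.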